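A few compounds are considered here, and "the series" means these few. Any claim that something is new, unique, unknown or untested is made for them only; others in the source may bear on it.

Working notes on the series.

Four compounds share one core. Compound 1 `O=C(CCCCC1CCSS1)NCc1cn(CCCCOc2ccc3cc(-c4ccc(Br)cc4)c(=O)oc3c2)nn1` and compound 2 `O=C(CCCCC1CCSS1)NCc1cn(CCCCOc2ccc3cc(-c4ccc(Cl)c(Cl)c4)c(=O)oc3c2)nn1` carry a four-carbon linker; compound 3 `O=C(CCCCC1CCSS1)NCc1cn(CCCCCOc2ccc3cc(-c4ccc(Br)cc4)c(=O)oc3c2)nn1` and compound 4 `O=C(CCCCC1CCSS1)NCc1cn(CCCCCOc2ccc3cc(-c4ccc(Cl)c(Cl)c4)c(=O)oc3c2)nn1` carry a five-carbon linker. Three of them are measured.

In a functional assay on PC-12 cells (Rattus norvegicus) for cytotoxicity, read by MTT assay, with stated times of 3 h and 2 h, tested at 10 uM (a lower number here means a weaker effect, a higher number a stronger effect of the compound at the concentration tested), compound 1 gives 42.6%. Compound 2 gives 58.9% in this assay. Compound 3 gives 48.4% in this assay.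

From compound 1 to compound 2 the change is 3,4-dichlorophenyl in place of 4-bromophenyl on an aromatic carbon. It produces a number 16.3 percentage points higher from compound 1 to compound 2 (beyond the scatter), a step beyond the scatter.

Compound 3 and compound 1 lie within the scatter of each other in this assay; compound 2 stands beyond the scatter from compound 3. How the core of compound 3 differs from the core of compound 1 is not broken down here.

Compound 4 is not yet measured. It differs from compound 3 by 3,4-dichlorophenyl in place of 4-bromophenyl on an aromatic carbon, the same kind of change as from compound 1 to compound 2, at a place described in the same words, so the two are taken as the same change at the same place.

Among the measured compounds shown here, for compound 4 a rise of about a number 14.6 percentage points higher from compound 3 to compound 4 (beyond the scatter) in this assay is expected, resting on the step of a number 16.3 percentage points higher from compound 1 to compound 2 (beyond the scatter) seen once with the shorter linker, with some margin for the single precedent. Compound 4 is therefore estimated at 63% in this assay, with a range from 50% to 76%.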

Compound 4, a percentage reported as activity, at one concentration (the size of the read-out at that concentration, not a potency): 59.4%
Compound 4: the middle estimate sits 3.6 percentage points above what was measured; the measured number falls inside the stated range.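

On the second core, the change of 4-bromophenyl to 3,4-dichlorophenyl on the same aromatic carbon gives a number 11 percentage points higher from compound 3 to compound 4 (beyond the scatter) in this assay. The step therefore keeps its direction on both cores, and its size cannot be told apart between them: the same change on two cores in this assay, a number 16.3 percentage points higher (beyond the scatter) from compound 1 to compound 2 and a number 11 percentage points higher (beyond the scatter) from compound 3 to compound 4, 5.3 percentage points apart, within the scatter of two such steps. Among the compounds shown here, this shows that the change carried over between these two closely related cores in this assay, but it rests on only two pairs, each read at one concentration, so it shows neither a rule for other cores nor a difference in potency, and it gives no reason for the rise.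

Because the change swaps the whole aryl group, the compounds shown leave open whether the rise follows from the loss of bromine, the chlorine in the group's 3-position, the chlorine in its 4-position or the pair of chlorines together, which 4-chlorophenyl, 3-chlorophenyl and unsubstituted phenyl would help to separate. They also leave open whether the step persists with a longer chain as the linker, or with an amine or a carboxylic acid on the phenyl ring in place of the halogens.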